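Swapping Chloro for Methoxy on a Shared Double Core

The compounds below may be only part of what the source reports. "The series", "measured", "known", "first", "only" and "open" are said of these compounds alone.

Two compounds share one large core and differ only in a single group on an aromatic carbon. Compound 1 `Cc1ccc(C(C2c3onc(C)c3N=C(c3ccccc3)CC2c2ccccc2)C2c3onc(C)c3N=C(c3ccccc3)CC2c2ccccc2)cc1` carries a methyl there, and in a functional assay on MCF7 cells (Homo sapiens) for cytotoxicity, read by MTT assay, with a stated time of 48 h (a lower number here means a stronger inhibitor, a higher number a weaker inhibitor), compound 1 gives 41.9 ug/mL. Compound 2 `Cc1noc2c1N=C(c1ccccc1)CC(c1ccccc1)C2C(c1ccc(Cl)cc1)C1c2onc(C)c2N=C(c2ccccc2)CC1c1ccccc1` carries a chloro in the same place, and in this assay compound 2 gives 59 ug/mL. For the measured compounds named here, compound 2 holds the higher of the two numbers measured so far, yet the step of a 1.4-fold higher number from compound 1 to compound 2 (0.15 log units; within the scatter) lies within the scatter, so the two compounds cannot be told apart.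

Compound 3 `COc1ccc(C(C2c3onc(C)c3N=C(c3ccccc3)CC2c2ccccc2)C2c3onc(C)c3N=C(c3ccccc3)CC2c2ccccc2)cc1` is the next member: methoxy in place of chloro on an aromatic carbon. Going by the values given here, only one measured step bears on this change, the exchange of methyl for chloro, which came out as a 1.4-fold higher number from compound 1 to compound 2 (0.15 log units; within the scatter) and stayed within the scatter. The move to methoxy is a change of the same kind at the same place, so no shift beyond the scatter is expected in this assay, an estimated step of a 1.2-fold lower number from compound 2 to compound 3 (0.07 log units; within the scatter). Compound 3 is therefore expected to give about 50 ug/mL in this assay, within a range from 25 ug/mL to 100 ug/mL.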

Compound 3, half-maximal inhibitory concentration: 57.3 ug/mL
Compound 3: the middle estimate sits 1.1-fold (0.06 log units) below what was measured; the measured number falls inside the stated range.
By their numbers in this assay, from the lowest: compounds 1, 3 and 2 (each within the scatter of the next).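

Methoxy brings a hydrogen-bond acceptor that chloro lacks, yet in this assay the exchange at this place gives a 1.0-fold lower number from compound 2 to compound 3 (0.01 log units; within the scatter) and the exchange of methyl for methoxy gives a 1.4-fold higher number from compound 1 to compound 3 (0.14 log units; within the scatter) on the same aromatic carbon. With the earlier step, this means that all three pairs among compound 1, compound 2 and compound 3 now lie within the scatter, so methyl, chloro and methoxy cannot be told apart at this place, para to a large group, in this cell assay. No supporting measurement is available to explain this lack of separation.

The three compounds shown cover only these small groups on the aromatic ring, so it remains open whether an amine, a carboxylic acid or a longer chain at the same place would also stay within the scatter or would move the number clearly. Going by these compounds, it is also open whether changes elsewhere on the shared core would shift the number, since all three compounds keep that core unchanged.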